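A few compounds are considered here, and "the series" means these few. Any claim that something is new, unique, unknown or untested is made for them only; others in the source may bear on it.

Measured so far in a functional assay on PC-3 cells (Homo sapiens) for antiproliferative activity, read by MTT assay, with a stated time of 24 h; on this read-out higher numbers stand for weaker inhibition and lower numbers for stronger inhibition:
- Compound 1 `CCn1c(C(=O)NCCN)ccc1C(CC)(CC)c1ccc(OCS(=O)(=O)c2ccccc2)c(C)c1` gives 6890 nM
- Compound 2 `CCn1c(C(=O)N[C@H](C)CO)ccc1C(CC)(CC)c1ccc(OCS(=O)(=O)c2ccccc2)c(C)c1` gives 7790 nM

Going by the values given here, compound 2 at 7790 nM cannot be separated from compound 1, the only other measured compound. The next compound, compound 3 `CCn1c(C(=O)NC(C)(C)CO)ccc1C(CC)(CC)c1ccc(OCS(=O)(=O)c2ccccc2)c(C)c1`, carries 1-(hydroxymethyl)-1-methylethyl in place of 1-(hydroxymethyl)ethyl on an amide-type nitrogen and otherwise matches compound 2.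

Among the compounds with values here, only one measured step bears on this change. On the same nitrogen, 1-(hydroxymethyl)ethyl in place of 2-aminoethyl gave a 1.1-fold higher number from compound 1 to compound 2 (0.05 log units; within the scatter) and so stayed within the scatter. Within the data shown here, that step is a single example and a different exchange, so it offers only loose guidance, and no measured pair shows the exchange made in compound 3. With that one exchange leaving the numbers in this assay within the scatter, no direction is favoured and no change beyond the scatter is expected. What is expected is a 1.0-fold lower number from compound 2 to compound 3 (0.02 log units; within the scatter) and thus nothing that could be told apart from the scatter. The estimate for compound 3 is 7500 nM with an expected range from 3500 nM to 16000 nM in repeated measurements.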

Compound 3, half-maximal inhibitory concentration: 9850 nM
For compound 3 the middle estimate is 1.3-fold (0.12 log units) below the measured one, within the range that was stated.
By their numbers in this assay, from the lowest: compounds 1, 2 and 3 (each within the scatter of the next).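

In this assay, 1-(hydroxymethyl)-1-methylethyl in place of 1-(hydroxymethyl)ethyl on the amide-type nitrogen gives a 1.3-fold higher number from compound 2 to compound 3 (0.10 log units; within the scatter) and so stays within the scatter, even though the leaving group has a defined stereocentre and the entering group has none. Set against the 2-aminoethyl group on the same nitrogen, the new group gives a 1.4-fold higher number from compound 1 to compound 3 (0.16 log units; within the scatter) and also stays within the scatter, so the three groups shown at this position cannot be told apart in this read-out. Nothing available here bears on why these groups give such similar numbers.

The compounds shown leave open whether any group on this nitrogen can move the number beyond the scatter, for example a carboxylic acid, a tertiary amine such as a dimethylamino chain, or a longer hydroxyalkyl chain. They also leave open whether the mirror-image form of 1-(hydroxymethyl)ethyl would read the same, and whether changes elsewhere on the shared core would matter more than this position does.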